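A few compounds are considered here, and "the series" means these few. Any claim that something is new, unique, unknown or untested is made for them only; others in the source may bear on it.

Working notes on the series built on the shared core of compound 1 (`CCCNC(=O)Nc1cccc2c1CN(C)CC2c1ccccc1`), read in a functional assay on the whole organism for inhibition, with Mus musculus as the target; a higher number here means that more compound is needed for the effect, a lower number that less compound is needed. Compound 1 reports only a limit (> 80 mg/kg). Compound 2 (`CCCCNCC(=O)Nc1cccc2c1CN(C)CC2c1ccccc1`) gives 32 mg/kg in this assay, and compound 3 (`CCCCNCCC(=O)Nc1cccc2c1CN(C)CC2c1ccccc1`) gives about 46 mg/kg there, so compound 3 stands within the scatter of compound 2 (a 1.4-fold higher number from compound 2 to compound 3 (0.16 log units; within the scatter)). Two further steps start from the limit and yield floors only (an at least 2.5-fold lower number from compound 1 to compound 2 (0.39 log units; beyond the scatter) and an at least 1.7-fold lower number from compound 1 to compound 3 (0.24 log units; that floor lies within the scatter)).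

The next change leads to compound 4 (`CN1Cc2c(NC(=O)CN3CCCC3)cccc2C(c2ccccc2)C1`) and is pyrrolidin-1-yl in place of (butylamino)methyl on a saturated chain carbon bound to a carbonyl carbon, in words pyrrolidin-1-yl in place of (butylamino)methyl on a saturated chain carbon bound to a carbonyl carbon. Within the data shown here, no measured step tests a ring at this place. The nearest guide is the step at the same place (a 1.4-fold higher number from compound 2 to compound 3 (0.16 log units; within the scatter)), which stayed within the scatter. No step beyond the scatter is therefore expected in this assay, and no direction is firmly indicated. The expected step is small (a 1.2-fold lower number from compound 3 to compound 4 (0.06 log units; within the scatter)). Estimated value for compound 4: 40 mg/kg (18 mg/kg to 85 mg/kg).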

Compound 4, dose for half-maximal effect: 39 mg/kg
Compound 4: middle estimate off by 1.0-fold (0.01 log units), on the high side; the range from low to high includes it.
By their numbers in this assay, from the lowest: compounds 2, 4 and 3 (each within the scatter of the next). At a limit, above all of these: compound 1.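

Pyrrolidin-1-yl brings the first ring to the saturated chain carbon bound to a carbonyl carbon, with 0 hydrogen-bond donors against 1 in (butylamino)methyl, and this assay gives a 1.2-fold lower number from compound 3 to compound 4 (0.07 log units; within the scatter) and a 1.2-fold higher number from compound 2 to compound 4 (0.09 log units; within the scatter) as the outcome. Closing the ring and losing that donor thus leave the number within the scatter of both open-chain amines. The reading against compound 1 is an at least 2.0-fold lower number from compound 1 to compound 4 (0.31 log units; beyond the scatter) and remains a floor only, because compound 1 stands at a limit: the limit of > 80 mg/kg in this assay, at which 1 of the 4 values shown sits.

Open, going by these compounds, is whether a piperidine, a morpholine or an open tertiary amine such as diethylamino fits this place equally well. Also open, on these data alone, is how pyrrolidin-1-yl behaves on the longer chain of compound 3.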